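The source may report more compounds than this note shows. Statements on the series, on what has been measured and on what is new or still open speak of the compounds shown alone.

Measured compounds:
compound 1 `CCOC(=O)c1cccc(-c2ccc([N+](=O)[O-])cc2)c1` — in an assay on COS-7 cells for inhibition of patatin-like phospholipase domain-containing protein 2 (Mus musculus), tested at 200 uM (a higher number here means more inhibition at the concentration tested (going by the name of the read-out), a lower number less inhibition), compound 1 gives 63%
compound 2 `CCOC(=O)c1cccc(-c2ccc(CN3CCCC3)cc2)c1` — in this assay compound 2 gives 33%

Compound 2 stands lowest of the two numbers shown, and its nearest neighbour is compound 1, reached by the step of a number 30 percentage points lower from compound 1 to compound 2 (beyond the scatter). Compound 3 `CCOC(=O)c1cccc(-c2ccc(CN(C)C)cc2)c1` differs from compound 2 by dimethylamino in place of pyrrolidin-1-yl on a saturated chain carbon bound to an aromatic carbon. Among the compounds with values here, no measured step swaps one amine for another; the only step known changes nitro for the whole (pyrrolidin-1-yl)methyl group, so it bears on this change only loosely. The expected step is therefore small, a number 5 percentage points lower from compound 2 to compound 3 (within the scatter), and compound 3 is estimated at 28%, from 10% to 50%.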

Compound 3, a percentage reported as inhibition, at one concentration (the size of the read-out at that concentration, not a potency): 67%
For compound 3 the middle estimate is 39 percentage points below the measured one; the whole stated range lies below it.
By their numbers in this assay, from the lowest: compound 2; then compounds 1 and 3 (each within the scatter of the next).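

In this assay, the choice of amine on the saturated chain carbon bound to an aromatic carbon clearly matters: dimethylamino in place of pyrrolidin-1-yl gives a number 34 percentage points higher from compound 2 to compound 3 (beyond the scatter) for this small swap. Exchanging nitro for (dimethylamino)methyl gives a number 4 percentage points higher from compound 1 to compound 3 (within the scatter), so replacing nitro with an amine-bearing group need not lower the read-out, and only the pyrrolidine of compound 2 stands apart. Nothing measured here explains the gap.

As far as these compounds go, whether diethylamino or piperidin-1-yl at this place would read like dimethylamino or like pyrrolidin-1-yl stays open. So does whether the ring as such, or its size, sets the number.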